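The source may report more compounds than this note shows. Statements on the series, on what has been measured and on what is new or still open speak of the compounds shown alone.

Three compounds sharing a chloromethylbenzyl-substituted core were examined in a functional assay on MCF7 cells (Homo sapiens) for cytotoxicity, read by sulforhodamine B assay, with a stated time of 48 h; on this read-out higher numbers stand for lower toxicity in this test and lower numbers for higher toxicity in this test. Compound 1 `ClCc1ccc(Cn2cnc3c(Cl)ncnc32)cc1` gives > 100000 nM, which is a limit of the assay rather than a number. Compound 3 `ClCc1ccc(Cn2cnc3c(Cl)nc(Cl)nc32)cc1` likewise gives > 100000 nM, again a limit. For the measured compounds named here, compound 2 `ClCc1ccc(Cn2cnc3nc(Cl)nc(Cl)c32)cc1` is the only one to return a number, 83200 nM. The difference between the cores of compound 2 and compound 3 is not broken down here. The change hydrogen in place of chloro on an aromatic carbon gave a step that the two limits leave unreadable from compound 3 to compound 1; the limit of > 100000 nM in this assay, at which 2 of the 3 values shown sit, keeps its size hidden. The same change, (hydrogen in place of chloro on an aromatic carbon), leads to compound 4 `ClCc1ccc(Cn2cnc3ncnc(Cl)c32)cc1`, not yet measured in this assay. Because compound 2 gives 83200 nM, compound 4 is expected to sit near 100000 nM, between 50000 nM and 250000 nM. This estimate means a step of a 1.2-fold higher number from compound 2 to compound 4 (0.08 log units; within the scatter).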

Compound 4, concentration lethal to 50% of the cells: 6450 nM
For compound 4 the middle estimate is 16-fold (1.19 log units) above the measured one; the whole stated range lies above it.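

In this assay, hydrogen in place of chloro on an aromatic carbon gave a 13-fold lower number from compound 2 to compound 4 (1.11 log units; beyond the scatter), so on the core of compound 2 this change lowers the number markedly. Whether it does the same on the core of compound 3 cannot be told, because the step from compound 3 to compound 1 cannot be read: the limit of > 100000 nM in this assay, at which 2 of the 4 values shown sit. For the compounds shown here, the one readable step therefore shows neither that the change carries from one core to the other nor that it fails to, and it holds only for this pair.

The compounds shown leave open what an amine or a methoxy group would give in place of the chloro that remains on compound 4. They also leave open what a plain methyl would give in place of the chloromethyl group.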